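A few compounds are considered here, and "the series" means these few. Any claim that something is new, unique, unknown or untested is made for them only; others in the source may bear on it.

Compound 1 `CCCCCCCCCCCCC/C=C/[C@@H](O)[C@H](COC(=O)CCCN(C)C)NC(=O)C(C)(C)C` gives 31000 nM in an assay on membranes from brain for inhibition of sphingomyelin phosphodiesterase 2 (Rattus norvegicus), using microsomes; on this read-out higher numbers stand for weaker inhibition and lower numbers for stronger inhibition.
Compound 2 `CCCCCCCCCCCCC/C=C/[C@@H](O)[C@H](COC(=O)NCCN(C(C)C)C(C)C)NC(=O)C(C)(C)C` gives 18000 nM in this assay.

For the measured compounds named here, compound 2 has the lowest of these two numbers, with compound 1 as its only neighbour; the step of a 1.7-fold lower number from compound 1 to compound 2 (0.24 log units; within the scatter) lies within the scatter, so the two cannot be ordered. Compound 3 `CCCCCCCCCCCCC/C=C/[C@@H](O)[C@H](COC(=O)NCCC(C)(C)C)NC(=O)C(C)(C)C` differs from compound 2 by tert-butyl in place of diisopropylamino on a saturated chain carbon, two bonds along the chain from an amide-type nitrogen. Going by the values given here, the only measured step, from compound 1 to compound 2, exchanged one amine-bearing chain for another and stayed within the scatter; no measured step removes the amine altogether, as the change to compound 3 does. Among the compounds with values here, the one step that bears on the question therefore argues for little movement, while the loss of the acceptor is untested. Compound 3 is thus expected near compound 2, with a wide range and a modest lean toward a higher number, estimated at 25000 nM (from 8000 nM to 80000 nM), a step of a 1.4-fold higher number from compound 2 to compound 3 (0.14 log units; within the scatter).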

Compound 3, half-maximal inhibitory concentration: 77000 nM
Compound 3: middle estimate off by 3.1-fold (0.49 log units), on the low side; measured number inside the range.
By their numbers in this assay, from the lowest: compounds 2 and 1 (each within the scatter of the next); then compound 3.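

In this assay, for the compounds shown here, tert-butyl in place of diisopropylamino on a saturated chain carbon, two bonds along the chain from an amide-type nitrogen, gives a 4.3-fold higher number from compound 2 to compound 3 (0.63 log units; beyond the scatter) and is the first step here to lie beyond the scatter. Going by these compounds alone, it is also the first change that leaves this chain without an amine, and a 2.5-fold higher number from compound 1 to compound 3 (0.40 log units; beyond the scatter) points the same way, so both amine-bearing compounds give lower numbers than the all-carbon compound 3. Nothing available explains this shift.

The step removes the nitrogen and also shortens the group from 7 heavy atoms to 4, so these two changes cannot be separated. An all-carbon group of the same size as diisopropylamino, such as 2,4-dimethylpent-3-yl, or a carboxylic acid at this place remains an open case in this assay.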